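Removing the Cyclopropyl from a Weakly Active Core

This account rests on a few compounds, and the source may have more. Where it says the series, first, only, none or still open, it means among the compounds named here.

Compound 1, `COc1ncc(-c2ccc3c(c2)N(c2ccc(C)cc2)C(=O)CO3)cc1NS(=O)(=O)c1ccc(F)cc1`: 4650 nM
Compound 2, `O=C1COc2ccc(-c3cccc(NS(=O)(=O)c4ccc(F)cc4)c3)cc2N1C1CC1`: a limit, > 40000 nM
Compound 3, `O=C1COc2ccc(-c3cnc(Cl)c(NS(=O)(=O)c4ccc(F)cc4)c3)cc2N1C1CCCCC1`: 14300 nM

In a functional assay on HeLa cells (Homo sapiens) for antiproliferative activity, read by MTT assay, with a stated time of 72 h (on this read-out higher numbers stand for weaker inhibition and lower numbers for stronger inhibition), compound 1 gives 4650 nM and compound 3 gives 14300 nM. Compound 2 is different: the assay reports no number for it, only a limit, > 40000 nM. That puts compound 2 at the limit of > 40000 nM in this assay, at which 1 of the 3 values shown sits, the one of the three without a measured value.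

Compound 4, `O=C1COc2ccc(-c3cccc(NS(=O)(=O)c4ccc(F)cc4)c3)cc2N1`, differs from compound 2 in one place: hydrogen in place of cyclopropyl on an amide-type nitrogen in a ring. No pair of measured compounds changes only this position, so the shown data give no measured size for such a step. The expected change is therefore small, no larger than the scatter: an at least 1.1-fold lower number from compound 2 to compound 4 (0.05 log units; that floor lies within the scatter). Compound 4 is estimated at 35000 nM, in a range from 8000 nM to 150000 nM.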

Compound 4, half-maximal inhibitory concentration: > 40000 nM
Compound 4 gave a limit, no number (the forecaster's own chance of this, stated with the estimate: 60%); middle value at least 1.1-fold (0.05 log units) from the limit.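

Compound 2 and compound 4 each give only a limit, not a number, so no step can be read between them: the limit of > 40000 nM in this assay, at which 2 of the 4 values shown sit. The compounds shown leave open how much hydrogen in place of cyclopropyl on an amide-type nitrogen in a ring changes the result in this assay.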